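Hydroxy for hydrogen: from compound 3 to compound 4

The source may hold more compounds than are shown below. What is called first, only, known or untested is meant among the compounds shown, and "the series" means these compounds.

Of the compounds shown here, three have been measured so far in a functional assay on HCT-116 cells (Homo sapiens) for antiproliferative activity; a lower number here means a stronger inhibitor, a higher number a weaker inhibitor. Compound 1 (`CC[C@H](C)[C@H]1C(=O)N[C@H](Cc2ccc(O)c(Br)c2)C(=O)N[C@@H](C(C)(C)O)C(=O)O[C@H](c2ccccc2)[C@H](C)/C=C/C=C(\C)[C@H](OC)C/C=C(\C)C(=O)N1C`) stands at 3.88 nM and compound 2 (`CC[C@H](C)[C@H]1C(=O)N[C@H](Cc2ccc(O)c(Br)c2)C(=O)N[C@@H](C(C)(C)O)C(=O)O[C@H](c2ccccc2)[C@H](C)/C=C/C=C(\C)[C@H](OC)C[C@@H]2O[C@@]2(C)C(=O)N1C`) at 1.59 nM there. Compound 3 (`CC[C@H](C)[C@H]1C(=O)N[C@H](Cc2cc(Cl)c(O)c(Cl)c2)C(=O)N[C@@H](C(C)C)C(=O)O[C@H](c2ccccc2)[C@H](C)/C=C/C=C(\C)[C@H](OC)C/C=C(\C)C(=O)N1C`) stands at 21.6 nM as the highest of the three numbers, and its gaps to both others lie beyond the scatter.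

Compound 4 (`CC[C@H](C)[C@H]1C(=O)N[C@H](Cc2cc(Cl)c(O)c(Cl)c2)C(=O)N[C@@H](C(C)(C)O)C(=O)O[C@H](c2ccccc2)[C@H](C)/C=C/C=C(\C)[C@H](OC)C/C=C(\C)C(=O)N1C`) departs from compound 3 in one place only: hydroxy in place of hydrogen on a saturated chain carbon bound to two saturated chain carbons and a saturated ring carbon. The same difference reads as isopropyl to 1-hydroxy-1-methylethyl.

Among the measured compounds shown here, no pair of measured compounds isolates this change. The expectation rests on compound 1, which carries 1-hydroxy-1-methylethyl and stands at 3.88 nM against compound 3, which carries isopropyl and stands at 21.6 nM in the same test. Compound 1 also differs from compound 3 elsewhere, and compound 4 keeps the halogens of compound 3, so the data do not show how much of that gap belongs to this one change. A lower number, probably beyond the scatter, is therefore expected (estimated step: a 3.6-fold lower number from compound 3 to compound 4 (0.56 log units; beyond the scatter)). The estimated value for compound 4 is 6 nM (expected range 2 nM to 18 nM).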

Compound 4, half-maximal inhibitory concentration: 1.6 nM
The estimate for compound 4 lay 3.8-fold (0.57 log units) above the measured number; measured number below the stated range.
By their numbers in this assay, from the lowest: compounds 2 and 4 (each within the scatter of the next); then compound 1; then compound 3.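

Among the compounds shown here, with the 3,5-dichloro-4-hydroxyphenyl group held constant, the change from isopropyl to 1-hydroxy-1-methylethyl on this saturated chain carbon now stands alone in one pair, and in this assay it gives a 14-fold lower number from compound 3 to compound 4 (1.13 log units; beyond the scatter), a large step that the earlier compounds could not separate from the difference in halogens. With 1-hydroxy-1-methylethyl held constant, 3,5-dichloro-4-hydroxyphenyl in place of 3-bromo-4-hydroxyphenyl gives a 2.4-fold lower number from compound 1 to compound 4 (0.38 log units; beyond the scatter), a modest step, so the hydroxy change is the large one of the two steps and the halogen change also lies beyond the scatter. Nothing measured here accounts for the size of either step.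

Going by these compounds, whether hydroxy gives a step of similar size on the core of compound 2 remains open, since that core appears here only with 3-bromo-4-hydroxyphenyl and 1-hydroxy-1-methylethyl. On these data alone, it is also open how this carbon would respond to a methoxy group or an amine in place of the hydroxy, or to a longer chain such as ethyl in place of one of its methyl groups.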